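Aryl group changes at the carbonyl carbon of compound 1

A few compounds are considered here, and "the series" means these few. Any claim that something is new, unique, unknown or untested is made for them only; others in the source may bear on it.

Compound 1 `COc1cc(-c2nnc3n2NC(c2ccco2)C(C(=O)c2cccc(Br)c2)S3)cc(OC)c1OC` — 63900 nM
Compound 2 `COc1cc(-c2nnc3n2NC(c2ccco2)C(C(=O)c2cccs2)S3)cc(OC)c1OC` — 46200 nM
Compound 3 `COc1cccc(C(=O)C2Sc3nnc(-c4cc(OC)c(OC)c(OC)c4)n3NC2c2ccco2)c1` — 84600 nM

In a functional assay on PC-3 cells (Homo sapiens) for cytotoxicity, read by MTT assay, with a stated time of 48 h (on this read-out lower numbers stand for stronger inhibition and higher numbers for weaker inhibition), compound 1 gives 63900 nM, the second highest of the three numbers. Its nearest neighbour is compound 3, a step that stays within the scatter a 1.3-fold higher number from compound 1 to compound 3 (0.12 log units; within the scatter); compound 2 stands furthest from it, also within the scatter a 1.4-fold lower number from compound 1 to compound 2 (0.14 log units; within the scatter). Compound 4 `COc1cc(-c2nnc3n2NC(c2ccco2)C(C(=O)c2cccc4ccccc24)S3)cc(OC)c1OC` has not yet been measured. It differs from compound 1 in one place: naphthalen-1-yl in place of 3-bromophenyl on a carbonyl carbon.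

Going by the values given here, two measured steps bear on this change, since they likewise exchange the group on the carbonyl carbon: a 1.4-fold lower number from compound 1 to compound 2 (0.14 log units; within the scatter) and a 1.8-fold higher number from compound 2 to compound 3 (0.26 log units; within the scatter). Both remain within the scatter, so the three measured groups at this position give numbers that cannot be told apart. Among the compounds with values here, no measured compound carries naphthalen-1-yl at the carbonyl carbon, so the data offer no basis for expecting the step to compound 4 to leave the scatter in either direction. Compound 4 is therefore expected to show a step of a 1.1-fold lower number from compound 1 to compound 4 (0.03 log units; within the scatter). The estimate for compound 4 is 60000 nM, with an expected range from 25000 nM to 150000 nM.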

Compound 4, half-maximal inhibitory concentration: > 100000 nM
Compound 4: no number, only a limit; the forecaster's own chance of this, stated with the estimate: 10%; at least 1.6-fold (0.22 log units) between middle value and limit.
By their numbers in this assay, from the lowest: compounds 2, 1 and 3 (each within the scatter of the next). At a limit, above all of these: compound 4.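

In this assay compound 4 gives no number, only a limit of the assay: the limit of > 100000 nM in this assay, at which 1 of the 4 values shown sits.

Until now, the groups on the carbonyl carbon could not be told apart, but naphthalen-1-yl, with its 2 six-membered aromatic rings of carbon only, gives the first separation at this position, an at least 2.1-fold higher number from compound 2 to compound 4 (0.33 log units; beyond the scatter). That separation holds only against thiophen-2-yl, since the floors of the other two steps, an at least 1.5-fold higher number from compound 1 to compound 4 (0.19 log units; that floor lies within the scatter) and an at least 1.1-fold higher number from compound 3 to compound 4 (0.07 log units; that floor lies within the scatter), do not establish a difference from 3-bromophenyl or 3-methoxyphenyl.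

The compounds shown leave open how far compound 4 lies past its limit, and so whether naphthalen-1-yl truly differs from those two groups. They also do not settle whether the second ring itself or its mode of attachment goes with this result, a question that naphthalen-2-yl on the same carbonyl carbon would address, and they say nothing about how a phenyl group carrying an amine or a carboxylic acid would read there.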